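Shared-core anilides: methyl removed from the side chain

The compounds below may be only part of what the source reports. "The series", "measured", "known", "first", "only" and "open" are said of these compounds alone.

Measured so far:
compound 1 `CCC(C)n1cnc2c(NCc3ccc(C(=O)Nc4ccccc4N)cc3)nc(Cl)nc21` — 65%
compound 2 `Nc1ccccc1NC(=O)c1ccc(Cn2cnc3c(NCc4ccccc4)nc(Cl)nc32)cc1` — 62.8%
compound 3 `CCCCn1cnc2c(Nc3cccc(Cl)c3)nc(NCOCc3ccc(C(=O)Nc4ccccc4N)cc3)nc21` — 63.1%

In a functional assay on HepG2 cells (Homo sapiens) for antiproliferative activity, read by CCK-8 assay, with a stated time of 72 h, tested at 8 uM (a higher number here means a stronger effect of the compound at the concentration tested, a lower number a weaker effect), compound 1 gives 65%. This is the highest of the three numbers, but only by margins that fall within the scatter: compound 3 gives 63.1% and compound 2 gives 62.8%, so the three compounds cannot be ranked on these data, and none may be called the strongest.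

The next compound, compound 4 `CCCn1cnc2c(NCc3ccc(C(=O)Nc4ccccc4N)cc3)nc(Cl)nc21`, has not been measured. It differs from compound 1 in one place only: hydrogen in place of methyl on a saturated chain carbon bound to an aromatic nitrogen and a saturated chain carbon. Put another way, sec-butyl becomes propyl on a saturated chain carbon bound to an aromatic nitrogen and a saturated chain carbon. For the measured compounds named here, no step between two measured compounds is on record for such a change, so there is no measured gauge for it. Given that compounds 1, 2 and 3, which differ far more among themselves, all sit within the scatter of one another, the loss of a single carbon from the chain is expected to produce no step beyond the scatter in this assay. Compound 4 is therefore estimated at 63%, with a range from 50% to 75%, which amounts to an expected step of a number 2 percentage points lower from compound 1 to compound 4 (within the scatter).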

Compound 4, a percentage reported as inhibition, at one concentration (the size of the read-out at that concentration, not a potency): 14.1%
The estimate for compound 4 lay 48.9 percentage points above the measured number; measured number below the stated range.
By their numbers in this assay, from the lowest: compound 4; then compounds 2, 3 and 1 (each within the scatter of the next).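

In this assay, hydrogen in place of methyl on a saturated chain carbon bound to an aromatic nitrogen and a saturated chain carbon, which reads as sec-butyl to propyl, gives a number 50.9 percentage points lower from compound 1 to compound 4 (beyond the scatter), a large step for the loss of one carbon and no other change. The earlier compounds shown here offered no one-place step at this position, and this pair shows that the read-out at the concentration tested is sensitive to the group carried here, with sec-butyl and propyl clearly apart on the shared core. Nothing in hand bears on what lies behind a step of this size, so the result stands as an observation only.

This single pair leaves open whether the step follows the methyl branch itself or is particular to these two chains, a question that isopropyl, tert-butyl or cyclopentyl at the same place would address on the core of compound 1. Also open, from the compounds shown here alone, is whether the same change keeps its size in a full concentration series rather than at one concentration, and on other members.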